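The source may report more compounds than this note shows. Statements on the series, on what has been measured and on what is new or still open speak of the compounds shown alone.

Measured compounds:
compound 1, `COc1cc(-c2cc(/C=C/C(=O)c3ccc(N)cc3)[nH]n2)cc(OC)c1OC`: 100%
compound 2, `COc1ccc(-c2cc(/C=C/C(=O)c3ccc(OC)c(OC)c3)[nH]n2)cc1`: 109%
compound 3, `COc1ccc(-c2cc(/C=C/C(=O)c3ccc(N)cc3)[nH]n2)cc1OC`: 99%

In a functional assay on K562 cells (Homo sapiens) for cytotoxicity, read by sulforhodamine B assay, with a stated time of 48 h, tested at 0.01 uM (a higher number here means a weaker effect of the compound at the concentration tested, a lower number a stronger effect), compound 1 gives 100%. Compound 3 gives 99% and compound 2 gives 109%; both values lie within the scatter of the value of compound 1, so the three measured compounds are not separated by this assay. Among the measured compounds shown here, the only single-place step measured, a number 1 percentage points lower from compound 1 to compound 3 (within the scatter), likewise moves nothing beyond the scatter.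

Compound 4, `COc1ccc(C(=O)/C=C/c2cc(-c3cc(OC)c(OC)c(OC)c3)n[nH]2)cc1`, differs from compound 1 as follows: methoxy in place of amino on an aromatic carbon. For the measured compounds named here, no measured step makes exactly this change. Compound 2 also carries methoxy where compound 1 carries amino, but differs from compound 1 in more than one place; its value sits within the scatter of the value of compound 1. Nothing in the measured numbers therefore points to a step beyond the scatter, and the expected step is a number 2 percentage points higher from compound 1 to compound 4 (within the scatter). Compound 4 is expected to give 102% in this assay, estimated between 88% and 116%.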

Compound 4, a percentage reported as activity, at one concentration (the size of the read-out at that concentration, not a potency): 97%
Compound 4: middle estimate off by 5 percentage points, on the high side, and the stated range covers the measured number.
By their numbers in this assay, from the lowest: compounds 4, 3, 1 and 2 (each within the scatter of the next, the first and the last beyond it).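

In this assay the exchange of amino for methoxy on the aromatic carbon para to a large group gives a number 3 percentage points lower from compound 1 to compound 4 (within the scatter) with the rest of compound 1 held fixed. Among the compounds shown here, compound 2 carries methoxy there only alongside other differences, so compound 4 gives the first direct reading of 4-aminophenyl to 4-methoxyphenyl, and at this one concentration that change does not move the read-out beyond the scatter. No measured evidence here bears on the size of this step.

As far as these compounds go, whether any other group at this position would separate from amino and methoxy stays open, for example hydroxyl, dimethylamino or a carboxylic acid. A single concentration also leaves open whether the same change would stay within the scatter at higher concentrations, where the read-out could differ.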